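Trifluoromethyl on the core: an untested change

This account rests on a few compounds, and the source may have more. Where it says the series, first, only, none or still open, it means among the compounds named here.

Measured compounds:
compound 1 `NCC1(c2cccc(-c3ccnc4[nH]ncc34)c2)CCC1`, 17 nM
compound 2 `NCC1(c2cccc(-c3ccnc4[nH]ncc34)c2)CCCC1`, 22 nM
compound 3 `NCC1(c2cccc(-c3ccnc4[nH]ncc34)c2)CCOCC1`, 9 nM

All three compounds share one core and were tested in an assay for inhibition of protein kinase C theta type (Homo sapiens), read by scintillation counting and 33P incorporation, with a stated time of 60 min, in the presence of a further agent that is not named here; a lower number here means a stronger inhibitor, a higher number a weaker inhibitor. Compound 1 stands second highest of the three numbers: its nearest neighbour is compound 2, reached by a 1.3-fold higher number from compound 1 to compound 2 (0.11 log units; within the scatter), and the furthest is compound 3, whose number is lower but still within the scatter of repeated measurements. The two steps among the measured compounds therefore show that changing the ring that carries the aminomethyl group moves the number little.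

Compound 4 `NCC1(c2cccc(-c3ccnc4[nH]nc(C(F)(F)F)c34)c2)CCC1` differs from compound 1 in a different place: trifluoromethyl in place of hydrogen on an aromatic carbon. Among the compounds with values here, none of the measured steps touches this part of the core, so nothing in the data shows how this assay responds to such a change. Without a guiding step, the expectation is a modest weakening with wide uncertainty: compound 4 is estimated at 40 nM, between 10 nM and 200 nM, which would mean a 2.4-fold higher number from compound 1 to compound 4 (0.37 log units; beyond the scatter).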

Compound 4, inhibition constant: 2 nM
Compound 4: middle estimate off by 20-fold (1.30 log units), on the high side; measured number below the stated range.
By their numbers in this assay, from the lowest: compound 4; then compounds 3, 1 and 2 (each within the scatter of the next, the first and the last beyond it).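

Trifluoromethyl in place of hydrogen on an aromatic carbon of the shared core gives an 8.5-fold lower number from compound 1 to compound 4 (0.93 log units; beyond the scatter) in this assay and lies beyond the scatter, whereas the one earlier step, made at the ring that carries the aminomethyl group, stayed within it. This position on the five-membered aromatic ring is therefore one where a change can move the number, and here a group of 4 heavy atoms in place of hydrogen gives a stronger inhibitor. Nothing in the information available explains this gain.

On these data alone, whether the gain is particular to trifluoromethyl remains open, since a methyl group, a chlorine atom or a nitrile at this position would test that. As far as these compounds go, it also remains open whether the same change would give a similar step in compound 2 or compound 3.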